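Dihydropyridine Aryloxyacetamides: From Acyl Hydrazide to Acyl Pyrazole

The source may report more compounds than this note shows. Statements on the series, on what has been measured and on what is new or still open speak of the compounds shown alone.

Compound 1 `CCOC(=O)C1=C(C)NC(C)=C(C(=O)OCC)C1c1ccc(OCC(=O)Nc2nc3ccccc3s2)cc1`: 47.7%
Compound 2 `CCOC(=O)C1=C(C)NC(C)=C(C(=O)OCC)C1c1ccc(OCC(=O)NNC(=O)c2ccccc2)cc1`: 9.1%
Compound 3 `CCOC(=O)C1=C(C)NC(C)=C(C(=O)OCC)C1c1ccc(OCC(=O)NNC(=O)c2sccc2Cl)cc1`: 10.6%

In a functional assay on the whole organism (strain Wistar) for inhibition, with Rattus norvegicus as the target, read by paw edema, with stated times of 30 min and 0.5 h, at a dose of 20 mg/kg (a higher number here means more inhibition at the dose given (going by the name of the read-out), a lower number less inhibition), compound 3 stands second highest of the three numbers; its nearest neighbour is compound 2, and the step of a number 1.5 percentage points higher from compound 2 to compound 3 (within the scatter) lies within the scatter, while the gap to compound 1 is large, as the step of a number 37.1 percentage points lower from compound 1 to compound 3 (beyond the scatter) shows. Compound 4 `CCOC(=O)C1=C(C)NC(C)=C(C(=O)OCC)C1c1ccc(OCC(=O)n2nc(C)cc2C)cc1` is the next one to be measured. The change from compound 3 is a group of 7 heavy atoms (5 carbon, 2 nitrogen; one five-membered aromatic ring with 2 hetero atoms) in place of a group of 10 heavy atoms (5 carbon, 2 nitrogen, 1 oxygen, 1 sulfur, 1 chlorine; one five-membered aromatic ring with 1 hetero atom), on a carbonyl carbon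

Two kinds of measured step bear on this. Exchanging the aryl group on the carbonyl carbon between compound 2 and compound 3 changed nothing beyond the scatter. Removing the hydrazide arrangement, as in the step of a number 38.6 percentage points lower from compound 1 to compound 2 (beyond the scatter) and the step of a number 37.1 percentage points lower from compound 1 to compound 3 (beyond the scatter), changed the numbers greatly. Compound 4 keeps the carbonyl but loses the hydrazide, so a rise in this assay is expected, though with wide uncertainty, giving an expected step of a number 14.4 percentage points higher from compound 3 to compound 4 (beyond the scatter). Compound 4 is therefore estimated at 25%, expected to fall between 5% and 50%.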

Compound 4, a percentage reported as inhibition, in the whole organism at one dose (the size of the read-out at that dose, not a potency): 13.7%
Compound 4: the middle estimate sits 11.3 percentage points above what was measured; the range from low to high includes it.
By their numbers in this assay, from the lowest: compounds 2, 3 and 4 (each within the scatter of the next); then compound 1.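

In this assay the 3,5-dimethyl-1H-pyrazol-1-yl group on the carbonyl carbon gives a result that cannot be told apart from either hydrazide (a number 3.1 percentage points higher from compound 3 to compound 4 (within the scatter); a number 4.6 percentage points higher from compound 2 to compound 4 (within the scatter)), so taking away the hydrazide arrangement does not by itself recover the number of compound 1. For the compounds shown here, the gap to the (1,3-benzothiazol-2-yl)amino group remains wide (a number 34 percentage points lower from compound 1 to compound 4 (beyond the scatter)), and among the four compounds only that group stands apart at this position. Nothing measured here accounts for this result.

The compounds shown leave open whether the higher number of compound 1 depends on the fused benzothiazole or on the amide hydrogen. A phenylamino or thiazol-2-ylamino group on this carbonyl carbon would bear on that question, and the same holds for an N-methyl-(1,3-benzothiazol-2-yl)amino group.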